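Aryl swap on the ring amide nitrogen: indolyl to dichlorophenyl

The source may hold more compounds than are shown below. What is called first, only, known or untested is meant among the compounds shown, and "the series" means these compounds.

Among the measured compounds shown here, compound 2 `CO[C@@H]1CC=C2N(c3c[nH]c4ccccc34)C(=O)C[C@]2(c2ccccc2)O1` gives 2300 nM in a functional assay on SK-BR-3 cells (Homo sapiens) for cytotoxicity, read by sulforhodamine B assay, with a stated time of 48 h (on this read-out lower numbers stand for stronger inhibition and higher numbers for weaker inhibition), the highest of the two numbers so far; compound 1 `CO[C@@H]1CC=C2N(c3ccc4[nH]ccc4c3)C(=O)C[C@]2(c2ccccc2)O1` gives 1300 nM, and the step is a 1.8-fold higher number from compound 1 to compound 2 (0.25 log units; within the scatter). Compound 3 `CO[C@@H]1CC=C2N(c3cc(Cl)cc(Cl)c3)C(=O)C[C@]2(c2ccccc2)O1` differs from compound 2 by 3,5-dichlorophenyl in place of 1H-indol-3-yl on an amide-type nitrogen in a ring. For the measured compounds named here, the single measured step, a 1.8-fold higher number from compound 1 to compound 2 (0.25 log units; within the scatter), only exchanges one indolyl isomer for another and stays within the scatter, so it bears little on replacing the indolyl by a dichlorophenyl with no hydrogen-bond donor. Nothing measured covers that change. Compound 3 is therefore expected to show a 1.1-fold higher number from compound 2 to compound 3 (0.04 log units; within the scatter), estimated at 2500 nM with a wide range from 700 nM to 9000 nM.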

Compound 3, half-maximal inhibitory concentration: 6540 nM
For compound 3 the middle estimate is 2.6-fold (0.42 log units) below the measured one; the range from low to high includes it.
By their numbers in this assay, from the lowest: compounds 1 and 2 (each within the scatter of the next); then compound 3.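

At this amide-type nitrogen in this assay the choice of aryl group now registers, where the two indolyl isomers stayed within the scatter. Putting 3,5-dichlorophenyl in place of an indolyl gives a 2.8-fold higher number from compound 2 to compound 3 (0.45 log units; beyond the scatter) and a 5.0-fold higher number from compound 1 to compound 3 (0.70 log units; beyond the scatter) with both steps beyond the scatter, so neither indolyl compound is matched by compound 3. No measurement in hand accounts for these steps.

Open, as far as these compounds go, is whether the change follows from the loss of the indole ring system or from the chlorine atoms. An unsubstituted phenyl, or a phenyl carrying an amine or a carboxylic acid, would bear on this.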